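A few compounds are considered here, and "the series" means these few. Any claim that something is new, unique, unknown or untested is made for them only; others in the source may bear on it.

Measured in an ADME assay on H9c2 cells (Rattus norvegicus) for cytotoxicity (a lower number here means a stronger inhibitor, a higher number a weaker inhibitor), each value being a limit and not a number:
- Compound 1 `CC(C)C(=O)Nc1nc2ccc(Cl)cc2s1`: > 50000 nM
- Compound 2 `O=C(CC1CC1)Nc1nc2ccc(Cl)cc2s1`: > 50000 nM
- Compound 3 `O=C(Nc1nc2ccc(Cl)cc2s1)C1CCOC1`: > 50000 nM

Compound 1 gives > 50000 nM, which is a limit. All the data share one feature: the limit of > 50000 nM in this assay, at which 3 of the 3 values shown sit.

Compound 4 `Clc1ccc2nc(NCC3CC3)sc2c1` has not been measured. It carries cyclopropylmethyl in place of isopropylcarbonyl on a nitrogen on an aromatic ring, so the carbonyl leaves.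

The measured steps bear on this only loosely: a step that the two limits leave unreadable from compound 1 to compound 2, a step that the two limits leave unreadable from compound 1 to compound 3 and a step that the two limits leave unreadable from compound 2 to compound 3. Each swaps a group on a carbonyl carbon, none removes the carbonyl, and none has a readable size.

The expected result is therefore a modest move towards a lower number, if any: an at least 1.2-fold lower number from compound 1 to compound 4 (0.09 log units; that floor lies within the scatter). The estimate for compound 4 is 40000 nM. Its expected range runs from 12000 nM to 80000 nM.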

Compound 4, half-maximal inhibitory concentration: > 50000 nM
Compound 4 gave a limit, no number; the forecaster's own chance of this, stated with the estimate: 55%; middle value at least 1.2-fold (0.09 log units) away from the limit.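

Compound 4 gives > 50000 nM, which is a limit and not a number, so its step from compound 1 cannot be read, because the data share one feature: the limit of > 50000 nM in this assay, at which 4 of the 4 values shown sit.

The compounds shown leave open whether cyclopropylmethyl in place of isopropylcarbonyl changes the read-out at all, and by how much.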